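Dimethylamino to Isopropyl(methyl)amino: A Step Within the Scatter

The source may report more compounds than this note shows. Statements on the series, on what has been measured and on what is new or still open speak of the compounds shown alone.

Compound 1 `Cc1ccccc1-c1nnc(NNC(C)C)s1`: 83 mg/kg
Compound 2 `Cc1ccccc1-c1nnc(NN(C)C)s1`: 60 mg/kg

Of the compounds shown here, two sharing one core have been measured in a functional assay on the whole organism with Mus musculus as the target, in the maximal electroshock model, with a stated time of 1 h; a higher number here means that more compound is needed for the effect, a lower number that less compound is needed. In this assay compound 1 gives 83 mg/kg, and compound 2 gives 60 mg/kg. Going by the values given here, the only measured step is a 1.4-fold lower number from compound 1 to compound 2 (0.14 log units; within the scatter), the change being dimethylamino in place of isopropylamino on a nitrogen on an aromatic ring. Compound 2 therefore stands beside compound 1, with nothing between them that exceeds the scatter.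

Compound 3 `Cc1ccccc1-c1nnc(NN(C)C(C)C)s1` has not yet been measured. It differs from compound 2 by isopropyl in place of methyl on an amine nitrogen. The change sits on the same amine nitrogen that the measured step touched, and that step, a 1.4-fold lower number from compound 1 to compound 2 (0.14 log units; within the scatter), was within the scatter. Among the compounds with values here, the single comparison available thus gives no reason to expect a shift in this assay beyond the scatter in either direction, and a wider alkyl group on this nitrogen has not yet been seen to move the number.

Compound 3 is therefore expected to give about 65 mg/kg, with a range from 35 mg/kg to 120 mg/kg, which would mean a step of a 1.1-fold higher number from compound 2 to compound 3 (0.03 log units; within the scatter).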

Compound 3, dose for half-maximal effect: 140 mg/kg
Compound 3: the middle estimate sits 2.2-fold (0.33 log units) below what was measured, and the stated range ends below it.
By their numbers in this assay, from the lowest: compounds 2, 1 and 3 (each within the scatter of the next, the first and the last beyond it).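

In this assay, the exchange of methyl for isopropyl on this amine nitrogen, whose other neighbours are a nitrogen on an aromatic ring and a saturated chain carbon, gave a 2.3-fold higher number from compound 2 to compound 3 (0.37 log units; beyond the scatter). Going by these compounds alone, this is the only step among the three compounds that passes the scatter, and it is a modest one, so the position is not indifferent to the alkyl group it carries, which the earlier comparison could not show. Methyl in place of hydrogen on the same nitrogen, with isopropyl kept, gave a 1.7-fold higher number from compound 1 to compound 3 (0.23 log units; within the scatter), so this change does not separate those two compounds, and no evidence is available on what lies behind either step.

The compounds shown leave open whether an ethyl group or a longer chain on this nitrogen would read with compound 2 or with compound 3. They also leave open how a cyclopropyl group, or a morpholine ring built on this nitrogen, would read in this assay.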